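The source may hold more compounds than are shown below. What is called first, only, known or untested is meant among the compounds shown, and "the series" means these compounds.

Compound 1 `O=C(Nc1ccccc1)C1CCN(C/C=C/c2ccccc2)CC1`: 57900 nM
Compound 2 `CCCc1ccc(NC(=O)C2CCN(C/C=C/c3ccccc3)CC2)cc1`: 5210 nM
Compound 3 `COc1cccc(NC(=O)C2CCN(C/C=C/c3ccccc3)CC2)c1`: 37200 nM

These values come from a functional assay on MGC-803 cells (Homo sapiens) for inhibition, read by MTT assay, with a stated time of 72 h; on this read-out higher numbers stand for weaker inhibition and lower numbers for stronger inhibition. Compound 3, at 37200 nM, stands level with compound 1, as a 1.6-fold lower number from compound 1 to compound 3 (0.19 log units; within the scatter) shows, while a 7.1-fold higher number from compound 2 to compound 3 (0.85 log units; beyond the scatter) sets it well apart from compound 2. Compound 4 `O=C(Nc1cccc(C(F)(F)F)c1)C1CCN(C/C=C/c2ccccc2)CC1` has trifluoromethyl in place of methoxy on an aromatic carbon. Within the data shown here, two steps bear on this change. Methoxy gave a 1.6-fold lower number from compound 1 to compound 3 (0.19 log units; within the scatter), whereas propyl gave an 11-fold lower number from compound 1 to compound 2 (1.05 log units; beyond the scatter). The incoming group is neither of these, so only a small move towards lower numbers is expected in this assay, namely a 1.7-fold lower number from compound 3 to compound 4 (0.23 log units; within the scatter). For compound 4 the estimated value is 22000 nM, with an expected range of 8000 nM to 55000 nM.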

Compound 4, half-maximal inhibitory concentration: 9590 nM
Compound 4: middle estimate off by 2.3-fold (0.36 log units), on the high side; the measured number falls inside the stated range.
By their numbers in this assay, from the lowest: compounds 2 and 4 (each within the scatter of the next); then compounds 3 and 1 (each within the scatter of the next).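

Placing trifluoromethyl on this aromatic carbon gives a 6.0-fold lower number from compound 1 to compound 4 (0.78 log units; beyond the scatter) when it replaces hydrogen and a 3.9-fold lower number from compound 3 to compound 4 (0.59 log units; beyond the scatter) when it replaces methoxy. Methoxy at the same place had left the number within the scatter of compound 1, so this position does respond to substitution, but the outcome depends on the group placed there. No measured evidence here explains the difference between these two groups.

Going by these compounds, whether an amine, a carboxylic acid or a nitrile at this place would also lower the number remains open. So does whether trifluoromethyl would act the same way on another carbon of this ring.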